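A few compounds are considered here, and "the series" means these few. Any claim that something is new, unique, unknown or untested is made for them only; others in the source may bear on it.

Measured so far, all in a functional assay on SF-295 cells (Homo sapiens) for inhibition, read by sulforhodamine B assay, with a stated time of 48 h; on this read-out lower numbers stand for stronger inhibition and higher numbers for weaker inhibition:

compound 1, `COc1cc(-c2nn(-c3cccc(NC(=O)c4ccc(Cl)c(C(F)(F)F)c4)c3)cc2-c2ccncc2)ccc1Cl`: 1380 nM
compound 2, `COc1cc(-c2nn(-c3cccc(NC(=O)Nc4ccc(Cl)c(C(F)(F)F)c4)c3)cc2-c2ccncc2)ccc1Cl`: 840 nM
compound 3, `COc1cc(-c2nn(-c3cccc(NC(=O)c4ccccc4)c3)cc2-c2ccncc2)ccc1Cl`: 340 nM

Among these three, compound 2 has the second highest number. Its nearest neighbour is compound 1, and that gap, a 1.6-fold lower number from compound 1 to compound 2 (0.22 log units; within the scatter), lies within the scatter, so the two cannot be told apart on these data. Compound 3 sits further off: a 2.5-fold lower number from compound 2 to compound 3 (0.39 log units; beyond the scatter) goes beyond the scatter, as does a 4.1-fold lower number from compound 1 to compound 3 (0.61 log units; beyond the scatter), so compound 3 gives the lowest number of the three.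

Compound 4, `O=C(Nc1cccc(-n2cc(-c3ccncc3)c(-c3ccc(Cl)c(O)c3)n2)c1)Nc1ccc(Cl)c(C(F)(F)F)c1`, is reached from compound 2 by one small change: hydrogen in place of methyl on an oxygen on an aromatic ring. The group on the carbonyl carbon, the only place where the three measured compounds differ from one another, is kept exactly as in compound 2. Among the measured compounds shown here, none of the measured steps touches the oxygen on the aromatic ring, so those steps, each modest or within the scatter, give no guidance on this change. For compound 4 the expected step is a 1.1-fold higher number from compound 2 to compound 4 (0.03 log units; within the scatter), that is, none beyond the scatter. Compound 4 is estimated to give 900 nM, with a range from 300 nM to 2700 nM.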

Compound 4, half-maximal inhibitory concentration: 740 nM
Beside the measured number, compound 4's estimate is 1.2-fold (0.09 log units) above it, and the stated range covers the measured number.
By their numbers in this assay, from the lowest: compound 3; then compounds 4, 2 and 1 (each within the scatter of the next).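

Replacing methoxy with hydroxy on the 4-chloro-3-methoxyphenyl group is the first change shown away from the group on the carbonyl carbon, and in this assay it gives a 1.1-fold lower number from compound 2 to compound 4 (0.06 log units; within the scatter). With the rest of compound 2 kept as it is, this oxygen can therefore carry either a methyl or a hydrogen without a difference that this cell read-out can separate from ordinary scatter, so the one carbon atom that leaves is not needed to hold the number at this level. Nothing measured alongside these compounds offers an explanation for this result.

The hydroxy group is shown only with the (4-chloro-3-(trifluoromethyl)phenyl)amino group on the carbonyl carbon, so whether the same swap would also leave the number unmoved with the plain phenyl of compound 3 remains open. Also open, as far as these compounds go, is what would happen with an ethyl group or a longer chain on this oxygen, or with an amine in place of the oxygen altogether.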